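A few compounds are considered here, and "the series" means these few. Any claim that something is new, unique, unknown or untested is made for them only; others in the source may bear on it.

Measured compounds:
Compound 1 `CN(C[C@H]1Cc2c(cccc2N2CCN(c3cccc(C(F)(F)F)c3)CC2)CN1)[C@H]1CCCc2cccnc21` gives 72.3% in an ADME assay on microsomes from liver (Mus musculus) for metabolic stability, read by LC-MS, with a stated time of 10 min; on this read-out higher numbers stand for a more stable compound and lower numbers for a less stable compound.
Compound 2 `CN(C[C@H]1Cc2c(cccc2N2CCN(c3ncccn3)CC2)CN1)[C@H]1CCCc2cccnc21` gives 35.1% in this assay.

Going by the values given here, of the two compounds measured so far, compound 2 stands lowest in this assay; its nearest neighbour is compound 1, and the only measured step, a number 37.2 percentage points lower from compound 1 to compound 2 (beyond the scatter), separates them. That step exchanges the aryl group on the ring nitrogen of the shared core and is large.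

Compound 3 `CN(C[C@H]1Cc2c(cccc2N2CCN(c3ccccn3)CC2)CN1)[C@H]1CCCc2cccnc21` has not yet been measured. It differs from compound 2 as follows: pyridin-2-yl in place of pyrimidin-2-yl on an amine nitrogen in a ring. Among the compounds with values here, the change sits at the same ring nitrogen as the one measured step, so that step is the only one that bears on it. The measured step shows that an exchange at this position can move the read-out in this assay far beyond the scatter.

Since compound 3 carries pyridin-2-yl, a group lying in its counted features between pyrimidin-2-yl and 3-(trifluoromethyl)phenyl, a rise is expected from compound 2, estimated as a number 14.9 percentage points higher from compound 2 to compound 3 (beyond the scatter). Compound 3 is therefore expected to give about 50% in this assay, within a range from 30% to 70%.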

Compound 3, percent of the compound remaining: 46.1%
Estimate against measurement, compound 3: 3.9 percentage points above, and the stated range covers the measured number.
By their numbers in this assay, from the lowest: compound 2; then compound 3; then compound 1.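

In this assay, the change at this amine nitrogen in a ring is no longer a single large exchange, as pyridin-2-yl in place of pyrimidin-2-yl gives a number 11 percentage points higher from compound 2 to compound 3 (beyond the scatter) and thus shows that the read-out responds even when the aromatic ring goes from 2 hetero atoms to 1 hetero atom, with the count of 6 heavy atoms unchanged. Pyridin-2-yl in place of 3-(trifluoromethyl)phenyl gives a number 26.2 percentage points lower from compound 1 to compound 3 (beyond the scatter) and so does not recover the number of compound 1. The three groups at this position therefore fall into an order, with each of the steps among them beyond the scatter: pyrimidin-2-yl lowest, pyridin-2-yl in the middle and 3-(trifluoromethyl)phenyl highest.

No measurement shown here gives a reason for these differences. On these data alone, it remains open where a plain phenyl, or a pyridin-2-yl carrying a trifluoromethyl or a methoxy group, would fall in this order, and whether the same order would hold on a core other than the shared one.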